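The source may report more compounds than this note shows. Statements on the series, on what has been measured and on what is new or still open speak of the compounds shown alone.

Measured so far:
compound 1 `COc1cc(CS(=O)(=O)c2nc3ccccc3[nH]2)ccc1OCc1ncc(C)c(OC)c1C`, 1820 nM
compound 2 `COc1cc(CS(=O)(=O)c2nc3ccccc3[nH]2)ccc1OCc1nccc(OCC(F)(F)F)c1C`, 1310 nM

In a functional assay on cells (Erythrocyte, Homo sapiens) (on this read-out lower numbers stand for stronger inhibition and higher numbers for weaker inhibition), compound 1 stands at the top of the two numbers, but compound 2 lies within the scatter of it, so the two are not separated. Compound 3 `COc1cc(CS(=O)(=O)c2nc3cc(OC(F)F)ccc3[nH]2)ccc1OCc1ncc(C)c(OC)c1C` is not yet measured in this assay. It differs from compound 1 by difluoromethoxy in place of hydrogen on an aromatic carbon. For the measured compounds named here, no measured pair shows what this change does here, so the expectation rests on the change alone. The expected step is small, toward a lower number if any, and not clearly beyond the scatter: a 1.5-fold lower number from compound 1 to compound 3 (0.18 log units; within the scatter). Compound 3 is therefore expected to give 1200 nM, within 400 nM to 3500 nM.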

Compound 3, half-maximal inhibitory concentration: 1420 nM
Compound 3: middle estimate off by 1.2-fold (0.07 log units), on the low side, and the stated range covers the measured number.
By their numbers in this assay, from the lowest: compounds 2, 3 and 1 (each within the scatter of the next).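

In this assay, for the compounds shown here, placing difluoromethoxy on this aromatic carbon gives a 1.3-fold lower number from compound 1 to compound 3 (0.11 log units; within the scatter) and is the first step read at this position. A group of 4 heavy atoms can therefore stand here without separating the two compounds on this read-out. The data offer no measured property that bears on this result. From the compounds shown here alone, whether an amine or a carboxylic acid on the same aromatic carbon would give a step beyond the scatter remains open. So does whether difluoromethoxy would give a similar step on the core of compound 2.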